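A few compounds are considered here, and "the series" means these few. Any claim that something is new, unique, unknown or untested is made for them only; others in the source may bear on it.

Working notes on the series. Compound 1 `C[C@H](NC(=S)Nc1cc(C(F)(F)F)cc(C(F)(F)F)c1)c1nc2ccccc2[nH]1` and compound 3 `CC(C)C[C@H](NC(=S)Nc1cc(C(F)(F)F)cc(C(F)(F)F)c1)c1nc2ccccc2[nH]1` are built on the core of compound 1; compound 2 `C[C@@H](NC(=S)NCc1ccccc1)c1nc2ccccc2[nH]1` and compound 4 `CC(C)C[C@@H](NC(=S)NCc1ccccc1)c1nc2ccccc2[nH]1` are built on the core of compound 2. The difference between the two cores is not broken down here.

In a functional assay on HeLa cells (Homo sapiens) for cytotoxicity, read by MTT assay (on this read-out lower numbers stand for stronger inhibition and higher numbers for weaker inhibition), compound 1 gives 133000 nM and compound 3 gives 18100 nM. The step of a 7.3-fold lower number from compound 1 to compound 3 (0.87 log units; beyond the scatter) belongs to the change (isopropyl in place of hydrogen on a saturated chain carbon, two bonds along the chain from an amide-type nitrogen and an aromatic carbon).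

Compound 2 is recorded in this assay as "not active" (no number reported), with no number behind that word. Going by the values given here, the change from compound 2 to compound 4 is isopropyl in place of hydrogen on a saturated chain carbon, two bonds along the chain from an amide-type nitrogen and an aromatic carbon, the same change at the same place as the one between compound 1 and compound 3.

For compound 4 in this assay a step of the size seen from compound 1 to compound 3 is expected, and this rests on the step of a 7.3-fold lower number from compound 1 to compound 3 (0.87 log units; beyond the scatter). Since compound 2 has no number, the starting point is open, and compound 4 may likewise return no number. Compound 4 is estimated at 100000 nM, expected between 30000 nM and 400000 nM.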

Compound 4, half-maximal inhibitory concentration: 21200 nM
Compound 4: middle estimate off by 4.7-fold (0.67 log units), on the high side; measured number below the stated range.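

Going by these compounds alone, no step from compound 2 to compound 4 can be read in this assay: compound 2 carries no number, while compound 4 gives 21200 nM. The compounds shown leave open whether isopropyl in place of hydrogen shifts the read-out on the core of compound 2 as it does on the core of compound 1. No measurement shown bears on a cause for this result.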